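The source may report more compounds than this note shows. Statements on the series, on what has been measured and on what is new or still open speak of the compounds shown alone.

Measured compounds in an ADME assay on HCT-116 cells (Homo sapiens) for cytotoxicity, read by CellTiter-Glo, with a stated time of 72 h; on this read-out lower numbers stand for stronger inhibition and higher numbers for weaker inhibition:
Compound 1 `CC1CCN(C2CCN(S(=O)(=O)c3cccc(Br)c3)CC2)CC1` gives > 5000 nM, a limit of the assay.
Compound 2 `Cc1cc(C)c(S(=O)(=O)N2CCC(C(=O)N3CCC(C)CC3)CC2)c(C)c1` gives > 5000 nM, also a limit.
Compound 3 `CC1CCN(C2CCN(S(=O)(=O)c3nccn3C)CC2)CC1` gives > 10000 nM, again a limit.

Compound 2 stands at the limit of > 5000 nM in this assay, at which 2 of the 3 values shown sit, in this assay; no number is known for it, and every value in the set is a limit. Among the compounds with values here, the only one-place step among the measured compounds, a step that the two limits leave unreadable from compound 1 to compound 3, runs between two limits and gives no readable size. Compound 4 `Cc1cc(C)c(S(=O)(=O)N2CCC(N3CC(C)CC(C)C3)CC2)c(C)c1` differs from compound 2 by 3,5-dimethylpiperidin-1-yl in place of (4-methylpiperidin-1-yl)carbonyl on a saturated ring carbon. Within the data shown here, no measured step bears on this change, so no size can be drawn from the data; the three limits suggest that the series sits beyond the reporting range of this assay, with no compound going against that. On this basis compound 4 is expected to remain at or beyond the limit, with a step that the limit leaves unreadable from compound 2 to compound 4 taken as no step beyond the scatter. The estimate for compound 4 is 8000 nM, with a range from 4000 nM to 20000 nM, and this assay is most likely to report only a limit again.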

Compound 4, half-maximal inhibitory concentration: > 5000 nM
Compound 4 was reported as a limit; the forecaster's own chance of this, stated with the estimate: 80%; the middle value lies beyond the limit too.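

In this assay compound 4 gives > 5000 nM, a limit of the assay. Compound 2 also stands only as a limit, and the step between the two cannot be read. The compounds shown leave open whether any change on the shared core gives a measurable value.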